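The compounds below may be only part of what the source reports. "The series", "measured", "known", "first", "only" and "open" are said of these compounds alone.

Measured so far in a functional assay on A549 cells (Homo sapiens) for inhibition, read by MTT assay, with a stated time of 24 h; a lower number here means a stronger inhibitor, a higher number a weaker inhibitor:
Compound 1 `CCOC(=O)C1=Cc2ccccc2OC1(OCc1cc(-c2ccc3ccccc3c2)no1)C(F)(F)F`: > 150000 nM, a limit of this assay.
Compound 2 `Cc1ccc(-c2cc(COC3(C(F)(F)F)Oc4ccccc4C=C3C(=O)O)on2)cc1`: 51200 nM.
Compound 3 `O=C(O)C1=Cc2ccccc2OC1(OCc1cc(-c2ccc([N+](=O)[O-])cc2)no1)C(F)(F)F`: > 150000 nM, again a limit.

Compound 3 stands at the limit, and compound 1 sits at the same limit. Only compound 2 gives a number. Going by the values given here, the one measured step, an at least 2.9-fold higher number from compound 2 to compound 3 (0.46 log units; beyond the scatter), runs from a number into the limit, so its size is a floor only, set by the limit of > 150000 nM in this assay, at which 2 of the 3 values shown sit. Compound 4 `O=C(O)C1=Cc2ccccc2OC1(OCc1cc(-c2ccc3ccccc3c2)no1)C(F)(F)F` differs from compound 3 by naphthalen-2-yl in place of 4-nitrophenyl on an aromatic carbon. Among the compounds with values here, no measured step follows this change directly. Compound 1 carries the same naphthalen-2-yl group with an ethyl ester instead of the acid and rests at the limit. Compound 2 carries a methyl on the phenyl and gives a number. The estimated step of an at least 1.5-fold lower number from compound 3 to compound 4 (0.17 log units; that floor lies within the scatter) is therefore a modest fall in the number, with a real chance of staying at the limit. Compound 4 is expected at 100000 nM, between 30000 nM and 300000 nM.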

Compound 4, half-maximal inhibitory concentration: > 150000 nM
Compound 4: no number, only a limit; the forecaster's own chance of this, stated with the estimate: 50%; middle value at least 1.5-fold (0.17 log units) away from the limit.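

In this assay, naphthalen-2-yl in place of 4-methylphenyl on this aromatic carbon gives an at least 2.9-fold higher number from compound 2 to compound 4 (0.46 log units; beyond the scatter), a floor only, so a second group joins 4-nitrophenyl in losing the readable number. The steps linking compound 4 to compound 3 and to compound 1 cannot be read, which leaves naphthalen-2-yl against 4-nitrophenyl, and the acid against the ethyl ester, unresolved. Most of the series now rests at one ceiling: the limit of > 150000 nM in this assay, at which 3 of the 4 values shown sit.

Still open, on these data alone, is how an unsubstituted phenyl or a 4-methoxyphenyl reads on this carbon. Also open, as far as these compounds go, is whether an ethyl ester or an amide in place of the acid shifts the number of compound 2.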